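Bromo at the pyridine carbon of compound 1

The source may report more compounds than this note shows. Statements on the series, on what has been measured and on what is new or still open speak of the compounds shown alone.

For the measured compounds named here, compound 1 `c1cncc(N2CC[C@H]3CN[C@H]3C2)c1` gives 48 nM in a functional assay on HEK293 cells for agonist activity at Neuronal acetylcholine receptor; alpha3/beta4 (Homo sapiens), read by FLIPR (on this read-out lower numbers stand for an effect already at smaller amounts and higher numbers for an effect only at larger amounts of compound), the second highest of the three numbers measured so far. Its mirror image, compound 2 `c1cncc(N2CC[C@@H]3CN[C@@H]3C2)c1`, gives 260 nM; the step of a 5.4-fold higher number from compound 1 to compound 2 (0.73 log units; beyond the scatter) is the largest in the set and rests on (the fact that compounds 1 and 2 differ only in the configuration as drawn). The chloro analogue, compound 3 `Clc1ccc(N2CC[C@H]3CN[C@H]3C2)cn1`, gives 29 nM, and the step of a 1.7-fold lower number from compound 1 to compound 3 (0.22 log units; within the scatter) stays within the scatter.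

Compound 4 `Brc1cncc(N2CC[C@H]3CN[C@H]3C2)c1` differs from compound 1 by bromo in place of hydrogen on an aromatic carbon, placed on an aromatic carbon of the six-membered ring with one nitrogen, two atoms from the ring nitrogen and meta to the group of eight heavy atoms. Going by the values given here, the only measured step with a halogen entering an aromatic carbon is a 1.7-fold lower number from compound 1 to compound 3 (0.22 log units; within the scatter), which did not move beyond the scatter; no bromo step has been measured. The step of a 1.6-fold lower number from compound 1 to compound 4 (0.20 log units; within the scatter) in this assay is therefore expected to be small, if anything toward a lower number. Compound 4 is estimated at 30 nM, within 12 nM to 90 nM.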

Compound 4, half-maximal effective concentration: 76 nM
Compound 4: middle estimate off by 2.5-fold (0.40 log units), on the low side; the measured number falls inside the stated range.
By their numbers in this assay, from the lowest: compounds 3, 1 and 4 (each within the scatter of the next, the first and the last beyond it); then compound 2.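

In this assay, bromo in place of hydrogen on the aromatic carbon two atoms from the ring nitrogen gives a 1.6-fold higher number from compound 1 to compound 4 (0.20 log units; within the scatter), so this position accepts a bromine atom with no readable change in the number. Alongside a 1.7-fold lower number from compound 1 to compound 3 (0.22 log units; within the scatter), this makes two halogen steps from compound 1, one chloro and one bromo, and neither lies beyond the scatter. No measurement available here bears on why the bromo step stays this small.

Still open, on these data alone, is whether the same aromatic carbon accepts a group other than a halogen, such as methoxy, a nitrile or an amine, with an equally small step. Also open, as far as these compounds go, is whether bromo at this carbon would give a similar step on the mirror-image core of compound 2.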